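A few compounds are considered here, and "the series" means these few. Any claim that something is new, unique, unknown or untested is made for them only; others in the source may bear on it.

Measured so far in a functional assay, with a stated time of 20 min, tested at 0.1 mM; on this read-out higher numbers stand for a stronger effect at the one concentration tested and lower numbers for a weaker effect:
compound 1 `COC(=O)c1c(O)c2ccccc2n(C)c1=O` gives 8.3%
compound 2 `COC(=O)c1c(O)c2ccccc2n(-c2ccccc2)c1=O` gives 9.1%

Compound 1 stands lowest of the two numbers, but the gap to compound 2 is within the usual scatter: a number 0.8 percentage points higher from compound 1 to compound 2 (within the scatter), with phenyl in place of methyl on an aromatic nitrogen. Both read-outs in this assay are small.

Compound 3 `Cn1c(=O)c(C(=O)NCCN)c(O)c2ccccc21` differs from compound 1 at the carbonyl carbon: (2-aminoethyl)amino in place of methoxy on a carbonyl carbon. Among the measured compounds shown here, no measured step touches this carbonyl carbon; the only known step, a number 0.8 percentage points higher from compound 1 to compound 2 (within the scatter), concerns the aromatic nitrogen and is within the scatter, so it gives no direction for a change at the carbonyl carbon. For the measured compounds named here, with both measured numbers small and no step bearing on the change, no step beyond the scatter is expected in this assay. Compound 3 is therefore estimated at 10% (range 0% to 30%), which means an expected step of a number 1.7 percentage points higher from compound 1 to compound 3 (within the scatter).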

Compound 3, a percentage reported as activity, at one concentration (the size of the read-out at that concentration, not a potency): 5.6%
Compound 3: the middle estimate sits 4.4 percentage points above what was measured; measured number inside the range.
By their numbers in this assay, from the lowest: compounds 3, 1 and 2 (each within the scatter of the next).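

Compound 3 changes the carbonyl carbon, which the earlier step on the aromatic nitrogen left untouched, and in this assay (2-aminoethyl)amino in place of methoxy gives a number 2.7 percentage points lower from compound 1 to compound 3 (within the scatter) on this read-out. Methoxycarbonyl and (2-aminoethyl)carbamoyl therefore cannot be told apart at the one concentration tested, and all the numbers on the shared core remain small. Nothing measured on these compounds bears on the reason for this result.

As far as these compounds go, it remains open whether a carboxylic acid, a simple primary amide or a longer aminoalkyl chain on the carbonyl carbon would give a step beyond the scatter. Also open, from the compounds shown here alone, is whether (2-aminoethyl)amino on the carbonyl carbon would read the same with phenyl in place of methyl on the aromatic nitrogen.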